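Piperidinyl to Chloroanilino: an Expected Cytotoxicity Step

A few compounds are considered here, and "the series" means these few. Any claim that something is new, unique, unknown or untested is made for them only; others in the source may bear on it.

Measured so far:
compound 1, `CCCCCCCCCCCCCCNc1nc(SCc2ccc(C(F)(F)F)cc2)nc2ccccc12`: > 50000 nM
compound 2, `FC(F)(F)c1ccc(CSc2nc(N3CCCCC3)c3ccccc3n2)cc1`: 25500 nM

Of the compounds shown here, two have been tested in a functional assay on PC-3 cells (Homo sapiens) for cytotoxicity, read by MTT assay, with a stated time of 72 h; on this read-out lower numbers stand for stronger inhibition and higher numbers for weaker inhibition. For compound 1 the result is a limit of the assay, > 50000 nM, and not a number. The result of compound 1 sits at the limit of > 50000 nM in this assay, at which 1 of the 2 values shown sits. Within the data shown here, compound 2 gives 25500 nM, the only number among the two results, so compound 2 stands alone as a measured point and no ranking against compound 1 can be drawn.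

Compound 3, `FC(F)(F)c1ccc(CSc2nc(Nc3cccc(Cl)c3)c3ccccc3n2)cc1`, differs from compound 2 in one place: (3-chlorophenyl)amino in place of piperidin-1-yl on an aromatic carbon. Among the measured compounds shown here, compounds 1 and 2 differ in more than one place, so no measured step tells what this single change does in this assay. The step is therefore expected to be small, at most a modest gain, a 1.7-fold lower number from compound 2 to compound 3 (0.23 log units; within the scatter). Compound 3 is estimated at 15000 nM, within a range of 4000 nM to 50000 nM.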

Compound 3, half-maximal inhibitory concentration: 13400 nM
Beside the measured number, compound 3's estimate is 1.1-fold (0.05 log units) above it, and the stated range covers the measured number.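

Among these compounds, compound 3 gives the first step that can be read at this position: in this assay, (3-chlorophenyl)amino in place of piperidin-1-yl gives a 1.9-fold lower number from compound 2 to compound 3 (0.28 log units; within the scatter). The position therefore takes a six-membered aromatic ring of carbon only, carrying chlorine and joined through a nitrogen with a hydrogen-bond donor, in place of a non-aromatic ring with no donor, and the two results stay within the usual scatter. The data shown give no reason for this outcome, and they cannot separate the part played by the aromatic ring from that of the chlorine or the donor.

On these data alone, it remains open how a morpholin-4-yl group or a plain anilino group without chlorine would read at this place. Also open, as far as these compounds go, is what a nitrile in place of the trifluoromethyl group, which all three compounds share, would do.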